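A Shorter Link on Compound 3: Expected Solubility of Compound 4

This account rests on a few compounds, and the source may have more. Where it says the series, first, only, none or still open, it means among the compounds named here.

Measured so far:
compound 1 `CN(C)CCCOc1ccc(-c2cc(=O)c3c(O)c(O)c(O)cc3o2)cc1` — 8.5 ug/mL
compound 2 `CN(C)C(=O)COc1ccc(-c2cc(=O)c3c(O)c(O)c(O)cc3o2)cc1` — 9.32 ug/mL
compound 3 `CCN(CC)C(=O)COc1ccc(-c2cc(=O)c3c(O)c(O)c(O)cc3o2)cc1` — 8.95 ug/mL

In a physicochemical assay for solubility, read by spectrophotometry (a higher number here means a more soluble compound, a lower number a less soluble compound), compound 3 sits in the middle of these three numbers, and all three lie within the scatter of one another: a 1.1-fold higher number from compound 1 to compound 3 (0.02 log units; within the scatter) and a 1.0-fold lower number from compound 2 to compound 3 (0.02 log units; within the scatter). Compound 4 `CCN(CC)C(=O)Oc1ccc(-c2cc(=O)c3c(O)c(O)c(O)cc3o2)cc1` differs from compound 3 in one place: diethylcarbamoyl in place of (diethylcarbamoyl)methyl on an oxygen on an aromatic ring. Going by the values given here, no measured step removes a chain atom from this link; the steps that do touch the side chain, a 1.1-fold higher number from compound 1 to compound 2 (0.04 log units; within the scatter) and a 1.0-fold lower number from compound 2 to compound 3 (0.02 log units; within the scatter), left the number where it was. Compound 4 is therefore expected to stay within the scatter of compound 3, with a step of a 1.0-fold higher number from compound 3 to compound 4 (0.00 log units; within the scatter). The estimate for compound 4 is 9 ug/mL, with a range from 5 ug/mL to 16 ug/mL.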

Compound 4, solubility: 9.23 ug/mL
Compound 4: middle estimate off by 1.0-fold (0.01 log units), on the low side; measured number inside the range.
By their numbers in this assay, from the lowest: compounds 1, 3, 4 and 2 (each within the scatter of the next).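

In this assay, going by these compounds alone, the change to diethylcarbamoyl from (diethylcarbamoyl)methyl on the oxygen gives a 1.0-fold higher number from compound 3 to compound 4 (0.01 log units; within the scatter) and is the first measured step that removes a chain atom from this link. The steps of a 1.0-fold lower number from compound 2 to compound 4 (0.00 log units; within the scatter) and a 1.1-fold higher number from compound 1 to compound 4 (0.04 log units; within the scatter) are also within the scatter, so all four compounds at this position now lie within the scatter of one another. Nothing available explains this result.

As far as these compounds go, whether a carboxylic acid on the side chain or a longer chain with a terminal amine would move the number remains open. So does the effect of replacing the carbamoyl group with a simple methyl on this oxygen.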